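Replacing 4-carboxyphenyl on the carbonyl carbon of compound 1

The source may report more compounds than this note shows. Statements on the series, on what has been measured and on what is new or still open speak of the compounds shown alone.

In a functional assay on DU-145 cells (Homo sapiens) for inhibition, read by trypan blue exclusion, with a stated time of 96 h (on this read-out lower numbers stand for stronger inhibition of growth and higher numbers for weaker inhibition of growth), compound 1 `O=C(O)c1ccc(C(=O)/C(=C\c2ccc(O)c([N+](=O)[O-])c2)SCc2ccc(Br)cc2)cc1` gives 50000 nM. Compound 2 `O=C(/C(=C\c1c(O)cc(O)cc1O)S(=O)(=O)c1ccccc1Br)c1ccc(Cl)cc1` gives 50000 nM, level with compound 1, and these two share the top of the three numbers in hand. Compound 3 `COc1cc(/C=C(/SCc2ccc(Br)cc2)C(=O)c2ccc(C(=O)O)cc2)ccc1F` gives 1000 nM.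

The change under review leads to compound 4 `O=C(/C(=C\c1ccc(O)c([N+](=O)[O-])c1)SCc1ccc(Br)cc1)c1ccc(O)cc1O`: 2,4-dihydroxyphenyl in place of 4-carboxyphenyl on a carbonyl carbon. In words, 2,4-dihydroxyphenyl stands in place of 4-carboxyphenyl on a carbonyl carbon, while the 4-hydroxy-3-nitrophenyl group of compound 1 stays.

For the measured compounds named here, only one measured step bears on this, and only indirectly. That step, a 50-fold lower number from compound 1 to compound 3 (1.70 log units; beyond the scatter), puts 4-fluoro-3-methoxyphenyl in place of 4-hydroxy-3-nitrophenyl on a double-bonded chain carbon, so it lies at a different place from the present change. Going by the values given here, it shows that this assay can move a long way, but no measured pair tests a swap on the carbonyl carbon. With compound 1 at the top of the numbers seen so far, a move towards a lower number is the more likely outcome, though smaller than the measured step and with a result level with compound 1 still possible.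

The expected change is a 5.0-fold lower number from compound 1 to compound 4 (0.70 log units; beyond the scatter). Compound 4 is estimated at 10000 nM, with an expected range from 2000 nM to 50000 nM.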

Compound 4, concentration for 50% growth inhibition: > 100000 nM
Compound 4: a limit, no number; the forecaster's own chance of this, stated with the estimate: 15%; middle value at least 10-fold (1.00 log units) away from the limit.
By their numbers in this assay, from the lowest: compound 3; then compounds 1 and 2 (each within the scatter of the next). At a limit, above all of these: compound 4.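

Compound 4 gives > 100000 nM in this assay, which is a limit of the assay and not a number. For the compounds shown here, this is the first reading for a change on the carbonyl carbon: 2,4-dihydroxyphenyl in place of 4-carboxyphenyl, with the 4-hydroxy-3-nitrophenyl group held, gives an at least 2.0-fold higher number from compound 1 to compound 4 (0.30 log units; that floor lies within the scatter), so the position shows no move towards a lower number, and because the floor of that step lies within the scatter, the size of any rise stays unsettled. The earlier compounds showed this assay moving only through the group on the double-bonded chain carbon, whereas this result gives the carbonyl position a reading that stands alone at the top of the series: the limit of > 100000 nM in this assay, at which 1 of the 4 values shown sits.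

Still open, going by these compounds, is whether the same swap would read differently with the 4-fluoro-3-methoxyphenyl group in place, since compound 3 at 1000 nM leaves room for movement in either direction. Also open is how a phenyl ring carrying an amine or a methyl ester would read on the carbonyl carbon, as the compounds shown do not establish what the 4-carboxyphenyl group itself contributes.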